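Extending the hexyl chain of compound 2 further

The source may report more compounds than this note shows. Statements on the series, on what has been measured and on what is new or still open speak of the compounds shown alone.

Among the measured compounds shown here, in a functional assay on MDA-MB-231 cells (Homo sapiens), read by microscopy and transwell migration, with a stated time of 24 h (a lower number here means a stronger inhibitor, a higher number a weaker inhibitor), compound 2 (`CCCCCCn1c(-c2ccc(C)cc2C)cs/c1=N\C(=O)c1ccccc1`) gives 45 nM, the lower of the two numbers measured so far. For the measured compounds named here, the only other measured compound, compound 1 (`CCCn1c(-c2ccc(C)cc2C)cs/c1=N\C(=O)c1ccccc1`), gives 292 nM. Compound 3 (`CCCCCCCCCCCCn1c(-c2ccc(C)cc2C)cs/c1=N\C(=O)c1ccccc1`) keeps the core of compound 2 and differs in its chain: hexyl in place of hydrogen on a saturated chain carbon, six bonds along the chain from an aromatic nitrogen. Going by the values given here, one measured step bears on this change, a 6.5-fold lower number from compound 1 to compound 2 (0.81 log units; beyond the scatter), where propyl entered in place of hydrogen on the chain. A single step establishes no trend, and the data do not show whether the number keeps falling as the chain grows longer. Resting on a 6.5-fold lower number from compound 1 to compound 2 (0.81 log units; beyond the scatter) alone, a further but smaller fall is expected in this assay, though a rise cannot be excluded. The expected change is a 1.8-fold lower number from compound 2 to compound 3 (0.26 log units; within the scatter). Compound 3 is expected at 25 nM, with an estimated range of 6 nM to 150 nM.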

Compound 3, half-maximal inhibitory concentration: 24 nM
Compound 3: the middle estimate sits 1.0-fold (0.02 log units) above what was measured; the measured number falls inside the stated range.
By their numbers in this assay, from the lowest: compounds 3 and 2 (each within the scatter of the next); then compound 1.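

In this assay, hexyl in place of hydrogen, six bonds along the chain from an aromatic nitrogen, gives a 1.9-fold lower number from compound 2 to compound 3 (0.27 log units; within the scatter), so compound 3 cannot be told apart from compound 2. Set against a 6.5-fold lower number from compound 1 to compound 2 (0.81 log units; beyond the scatter), this shows that the number does not keep falling measurably with this further length, although nothing measured so far shows a loss either. The longer chain of compound 3 still stands well clear of the propyl chain of compound 1, with a 12-fold lower number from compound 1 to compound 3 (1.09 log units; beyond the scatter).

Nothing available explains why the chain length acts in this way. From the compounds shown here alone, whether a longer chain would leave the number unchanged or raise it stays open, as does the effect of an amine or a carboxylic acid on the chain.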